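A Sulfonyl Swap on the Ring Nitrogen of Compound 1

The source may report more compounds than this note shows. Statements on the series, on what has been measured and on what is new or still open speak of the compounds shown alone.

Compound 1 `CC1CC(C(=O)N2CCc3nc(C#Cc4ccccc4)sc3C2)C1` and compound 2 `CC1CCCC(C(=O)N2CCc3nc(C#Cc4ccccc4)sc3C2)C1` share one core and differ only in the carbon ring attached to the carbonyl carbon. In an assay on HEK293 cells for positive allosteric modulation of metabotropic glutamate receptor 5 (Homo sapiens), read by FLIPR, with a stated time of 1 h (on this read-out higher numbers stand for an effect only at larger amounts of compound and lower numbers for an effect already at smaller amounts), compound 1 gives 81 nM, and compound 2 gives 100 nM. Compound 1 shows the lowest of the two numbers, yet the step of a 1.2-fold higher number from compound 1 to compound 2 (0.09 log units; within the scatter) lies within the scatter, so the two compounds stand together rather than apart.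

Compound 3 `O=S(=O)(C1CC1)N1CCc2nc(C#Cc3ccccc3)sc2C1` is not yet measured and alters compound 1 more deeply: cyclopropylsulfonyl in place of (3-methylcyclobutyl)carbonyl on an amine nitrogen in a ring. Here the carbonyl itself gives way to a sulfonyl, and the four-membered ring to a three-membered one.

Among the compounds with values here, the single measured step, from compound 1 to compound 2, exchanges one carbon ring for another while keeping the carbonyl, and it stays within the scatter. Within the data shown here, no measured pair bears on replacing a carbonyl by a sulfonyl, so the direction of this change cannot be read from the data. The step of a 2.5-fold higher number from compound 1 to compound 3 (0.39 log units; beyond the scatter) is therefore only an expectation resting on an unexplored change. For compound 3 in this assay an estimate of 200 nM is expected, within a range from 50 nM to 800 nM.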

Compound 3, half-maximal effective concentration: > 10000 nM
Compound 3 was reported as a limit; the forecaster's own chance of this, stated with the estimate: 10%; middle value at least 50-fold (1.69 log units) away from the limit.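

Within the data shown here, on the amine nitrogen in the ring, this change reaches much further than anything the earlier compounds showed. In this assay, exchanging one carbon ring for another while keeping the carbonyl gives a 1.2-fold higher number from compound 1 to compound 2 (0.09 log units; within the scatter), whereas replacing (3-methylcyclobutyl)carbonyl with cyclopropylsulfonyl gives an at least 120-fold higher number from compound 1 to compound 3 (2.09 log units; beyond the scatter). The result for compound 3 is a limit of the assay and not a number, so this step has a lower bound but no exact size: the limit of > 10000 nM in this assay, at which 1 of the 3 values shown sits.

Within these three compounds, then, the group on this nitrogen can hold its effect through a change of carbon ring with the carbonyl in place, but not through this swap, in which the sulfonyl and the three-membered ring enter together. The compounds shown leave open which of those two parts carries the step, a question that cyclopropylcarbonyl or (3-methylcyclobutyl)sulfonyl on the same nitrogen would address by changing only one part, and they also leave open how a simple methylsulfonyl or a longer chain on a sulfonyl would read.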